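Chloro in place of hydrogen: a step on the hydrazone ring

The source may hold more compounds than are shown below. What is called first, only, known or untested is meant among the compounds shown, and "the series" means these compounds.

Measured compounds:
Compound 1, `O=C(N/N=C/c1cccc(Cl)c1)c1cccnc1Nc1cccc(C(F)(F)F)c1`: 76.7%
Compound 2, `COc1cc(/C=N/NC(=O)c2cccnc2Nc2cccc(C(F)(F)F)c2)cc(OC)c1OC`: 54.4%
Compound 3, `CNc1ncccc1C(=O)N/N=C/c1ccccc1`: 67.6%

Of the compounds shown here, three have been tested in a functional assay on the whole organism (strain Wistar) for inhibition, with Rattus norvegicus as the target, read by paw edema, with a stated time of 1 h, at a dose of 10 mg/kg by the intraperitoneal route; a higher number here means more inhibition at the dose given (going by the name of the read-out), a lower number less inhibition. Compound 1 gives 76.7%, compound 2 gives 54.4% and compound 3 gives 67.6%. Compound 3 stands second of the three: its number lies within the scatter of compound 1 and beyond the scatter of compound 2, so it can be told apart from compound 2 but not from compound 1.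

The next compound, compound 4 with the structure `CNc1ncccc1C(=O)N/N=C/c1cccc(Cl)c1`, has not been measured. It differs from compound 3 in one place: chloro in place of hydrogen on an aromatic carbon, on an aromatic carbon of a six-membered aromatic ring of carbon only, meta to a large group. For the measured compounds named here, no pair of measured compounds shows this change alone, so its effect in this assay is not known from the data. Compound 1 also carries a chloro group at the corresponding place and gives 76.7%, but its core differs from compound 3 elsewhere, so that value is only a loose hint.

The step from compound 3 to compound 4 is expected to be small, a number 3.4 percentage points higher from compound 3 to compound 4 (within the scatter), and not beyond the scatter. For compound 4 the estimate in this assay is 71%, with a range from 58% to 84%.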

Compound 4, a percentage reported as inhibition, in the whole organism at one dose (the size of the read-out at that dose, not a potency): 68.6%
Estimate against measurement, compound 4: 2.4 percentage points above; low and high end bracket the measured number.
By their numbers in this assay, from the lowest: compound 2; then compounds 3, 4 and 1 (each within the scatter of the next).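

In this assay, for the compounds shown here, the pair gives the first direct reading of chloro in place of hydrogen on an aromatic carbon of the six-membered aromatic ring of carbon only, meta to a large group, with a number 1 percentage points higher from compound 3 to compound 4 (within the scatter). Going by these compounds alone, the two compounds cannot be told apart at this dose, so with the core of compound 3 held constant, this single replacement leaves the read-out within the usual scatter, which the earlier compounds, none of them differing in only one place, could not show. Nothing in the data bears on why the chloro group has so small a measured effect here.

As far as these compounds go, it remains open whether a different group at this same place, such as fluoro, a nitrile, an amine or a carboxylic acid, would give a step beyond the scatter. From the compounds shown here alone, because this read-out reflects one dose and one stated time, it also remains open whether the two compounds would still be indistinguishable at another dose or time, or whether chloro would behave the same way on another core.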